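Thiourea series: nitro in place of methoxy on the aryl ring

The compounds below may be only part of what the source reports. "The series", "measured", "known", "first", "only" and "open" are said of these compounds alone.

Of the compounds shown here, three have been measured in a functional assay on U-373MG ATCC cells (Homo sapiens) for inhibition, read by MTT assay, with a stated time of 72 h; a lower number here means a stronger inhibitor, a higher number a weaker inhibitor. Compound 1 `COc1cccc(NC(=S)NC2CC(C)(C)Oc3ccc(Br)cc32)c1` gives 66000 nM. Compound 3 `CC1(C)CC(NC(=O)Nc2ccccc2)c2cc(Cl)ccc2O1` gives 68000 nM; its number and that of compound 1 lie within the scatter of each other, so no order between them can be stated. Compound 2 `CC1(C)CC(NC(=S)Nc2cccc(C#N)c2)c2cc(Cl)ccc2O1` gives 7000 nM, the lowest of the three numbers and beyond the scatter from compound 1. Compound 1 therefore stands with compound 3 at the high end of the numbers seen so far, with compound 2 well below both.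

Compound 4 `CC1(C)CC(NC(=S)Nc2cccc([N+](=O)[O-])c2)c2cc(Br)ccc2O1` has not yet been measured in this assay. It differs from compound 1 in one place: nitro in place of methoxy on an aromatic carbon. The aryl substituent sits on an aromatic carbon of a six-membered aromatic ring of carbon only, meta to a large group. Among the measured compounds shown here, compound 2 carries a different substituent at the corresponding position and also a different halogen on the core, so no single step isolates the aryl substituent; the comparison is indirect.

The step is expected to be a 4.4-fold lower number from compound 1 to compound 4 (0.64 log units; beyond the scatter). This expected lowering would lie beyond the scatter yet remain smaller than the gap between compound 1 and compound 2. Compound 4 is estimated at 15000 nM, within a range of 4000 nM to 50000 nM.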

Compound 4, half-maximal inhibitory concentration: 4000 nM
Compound 4: middle estimate off by 3.8-fold (0.57 log units), on the high side, within the range that was stated.
By their numbers in this assay, from the lowest: compounds 4 and 2 (each within the scatter of the next); then compounds 1 and 3 (each within the scatter of the next).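

In this assay, among the compounds shown here, the aryl substituent now has a comparison that changes one place only, which the earlier compounds did not offer: nitro in place of methoxy gives a 17-fold lower number from compound 1 to compound 4 (1.22 log units; beyond the scatter), with the rest of the structure unchanged. This aromatic carbon, meta to a large group, is therefore not indifferent to what it carries, at least for this pair of thioureas. No measurement of any property of the two groups is available to account for the size of this step.

On these data alone, whether the same step holds on the chlorine-bearing core or with the urea in place of the thiourea stays open. As far as these compounds go, how an amine, a carboxylic acid or a trifluoromethyl group would read on this carbon is also open, since only methoxy and nitro can be compared here.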